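Swapping trifluoromethyl for fluoro on the aromatic ring

This account rests on a few compounds, and the source may have more. Where it says the series, first, only, none or still open, it means among the compounds named here.

Measured compounds and their readings in a functional assay on LNCaP cells (Homo sapiens) for cytotoxicity, read by MTT assay, with a stated time of 72 h; a lower number here means a stronger inhibitor, a higher number a weaker inhibitor:
compound 1 `CC1=C(/C=C/C(=O)/C=C/c2ccccc2F)C(C)(C)CCC1` gives 10700 nM
compound 2 `CC1=C(/C=C/C(=O)/C=C/c2ccccc2)C(C)(C)CCC1O` gives 5800 nM
compound 3 `CC1=C(/C=C/C(=O)/C=C/c2ccccc2C(F)(F)F)C(C)(C)CCC1O` gives 2900 nM

Compound 3 has the lowest of the three numbers in this assay. Its nearest neighbour is compound 2, and that difference lies within the usual scatter of the measurement, so the two cannot be ranked; compound 1 lies further off, beyond the scatter. Compound 4 `CC1=C(/C=C/C(=O)/C=C/c2ccccc2F)C(C)(C)CCC1O` arises from compound 3 by fluoro in place of trifluoromethyl on an aromatic carbon. Among the measured compounds shown here, only one measured step touches this part of the molecule: a 2.0-fold lower number from compound 2 to compound 3 (0.30 log units; within the scatter). Putting a trifluoromethyl group in place of hydrogen thus moved the number only within the scatter. For the measured compounds named here, compound 4 keeps the hydroxyl that compounds 2 and 3 share; compound 1, which also carries fluoro but lacks that hydroxyl, shows only what such a compound without the hydroxyl gave, and no step from it to compound 4 is known. A change from trifluoromethyl to fluoro is therefore expected to shift the number little, at most a modest rise: the expected step is a 1.6-fold higher number from compound 3 to compound 4 (0.19 log units; within the scatter). Compound 4 is estimated at 4500 nM, within a range from 2000 nM to 10000 nM.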

Compound 4, half-maximal inhibitory concentration: 2900 nM
Estimate against measurement, compound 4: 1.6-fold (0.19 log units) above, within the range that was stated.
By their numbers in this assay, from the lowest: compounds 3, 4, 2 and 1 (each within the scatter of the next, the first and the last beyond it).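

In this assay, fluoro in place of trifluoromethyl on this aromatic carbon gives no change at the digits printed from compound 3 to compound 4 (within the scatter) and so the two groups cannot be told apart here. Set against the bare ring, fluoro gives a 2.0-fold lower number from compound 2 to compound 4 (0.30 log units; within the scatter) and thus cannot be separated from hydrogen at this position either, so this spot has shown no clear response to any of the three. Among the compounds shown here, the only step beyond the scatter lies elsewhere in the molecule: hydroxy in place of hydrogen on a saturated ring carbon gives a 3.7-fold lower number from compound 1 to compound 4 (0.57 log units; beyond the scatter) as a modest gain, now read with the fluoro held fixed.

As far as these compounds go, how an amine or a carboxylic acid on this aromatic carbon would read remains open. Nothing given here explains these readings.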